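Trifluoromethyl Tetrazolyl Variant of a Spiro Substance-P Ligand

A few compounds are considered here, and "the series" means these few. Any claim that something is new, unique, unknown or untested is made for them only; others in the source may bear on it.

Among the measured compounds shown here, compound 1 `COc1ccc(F)cc1[C@H]1COCC2(C1)OCCN[C@H]2c1ccc(F)cc1` is the first reference point; in an assay on CHO cells for displacement of a labelled ligand from Substance-P receptor (Homo sapiens) (a lower number here means a stronger inhibitor, a higher number a weaker inhibitor), compound 1 gives 10 nM. Compound 2 `COc1ccc(C(F)(F)F)cc1[C@H]1COCC2(C1)OCCN[C@H]2c1ccc(F)cc1` carries a trifluoromethyl where compound 1 carries a fluoro, and in this assay compound 2 gives 1.3 nM. That single change produced a 7.7-fold lower number from compound 1 to compound 2 (0.89 log units; beyond the scatter). Among the two numbers in hand, compound 2 therefore stands with the lowest number, and its nearest neighbour is compound 1.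

Compound 3 `COc1ccc(-n2nnnc2C(F)(F)F)cc1[C@H]1COCC2(C1)OCCN[C@H]2c1ccc(F)cc1` follows from compound 2 by the change (5-(trifluoromethyl)-1H-tetrazol-1-yl in place of trifluoromethyl on an aromatic carbon). For the measured compounds named here, no measured step bears directly on this exchange: the only step in hand, the one from compound 1 to compound 2, swaps a fluoro for a trifluoromethyl and says nothing about replacing a trifluoromethyl with 5-(trifluoromethyl)-1H-tetrazol-1-yl. The expectation for compound 3 in this assay therefore rests mainly on compound 2, and the step is estimated as a 3.1-fold higher number from compound 2 to compound 3 (0.49 log units; beyond the scatter), a shift of uncertain direction and modest size. The estimate for compound 3 is 4 nM, with a range from 1 nM to 20 nM.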

Compound 3, half-maximal inhibitory concentration: 0.1 nM
Beside the measured number, compound 3's estimate is 40-fold (1.60 log units) above it; measured number outside the range, below it.
By their numbers in this assay, from the lowest: compound 3; then compound 2; then compound 1.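

At the aromatic carbon para to the methoxy group, the first pair showed only that trifluoromethyl gives a lower number than fluoro in this assay. Exchanging trifluoromethyl for 5-(trifluoromethyl)-1H-tetrazol-1-yl gives a 13-fold lower number from compound 2 to compound 3 (1.11 log units; beyond the scatter) in this series, so the position accepts a group of 9 heavy atoms in place of one of 4, with a five-membered aromatic ring and 4 hydrogen-bond acceptors where trifluoromethyl has none, and the number still falls. Taken from the fluoro end, the position now spans a 100-fold lower number from compound 1 to compound 3 (2.00 log units; beyond the scatter) on the same core, yet no measurement at hand accounts for this gain.

As far as these compounds go, whether the gain belongs to the tetrazole ring or to the trifluoromethyl it carries stays open, and a 1H-tetrazol-1-yl bearing a methyl group or only hydrogen at its 5-position would separate the two. How the number responds to a group of another kind at this carbon, such as an amine, a carboxylic acid or a longer chain, also remains unknown from the three compounds shown.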